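Methoxy for chloro on two cores of one series

This account rests on a few compounds, and the source may have more. Where it says the series, first, only, none or still open, it means among the compounds named here.

Compound 1 `Clc1ccc(-c2nnc(-c3nsc4ccccc34)o2)cc1` and compound 2 `COc1ccc(-c2nnc(-c3nsc4ccccc34)o2)cc1` share one core and differ in a single place. In a functional assay on the whole organism for inhibition, with Rattus norvegicus as the target, with a stated time of 2 h, at a dose of 100 mg/kg by the intraperitoneal route (a higher number here means more inhibition at the dose given (going by the name of the read-out), a lower number less inhibition), compound 1 gives 50%, and compound 2 gives 45%. The change between them is methoxy in place of chloro on an aromatic carbon, and its step is a number 5 percentage points lower from compound 1 to compound 2 (within the scatter). Compound 3 `Clc1ccc(Nc2nnc(-c3nsc4ccccc34)o2)cc1` carries a different core; how the two cores differ is not broken down here. In this assay compound 3 gives 48%, a number within the scatter of both compound 1 and compound 2. Compound 4 `COc1ccc(Nc2nnc(-c3nsc4ccccc34)o2)cc1` is not yet measured; it differs from compound 3 by methoxy in place of chloro on an aromatic carbon, the same change as between compound 1 and compound 2. Because a number 5 percentage points lower from compound 1 to compound 2 (within the scatter) stays within the scatter, the step from compound 3 to compound 4 is expected to be a number 4 percentage points lower from compound 3 to compound 4 (within the scatter). Compound 4 is therefore estimated at 44%, between 30% and 58%.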

Compound 4, a percentage reported as inhibition, in the whole organism at one dose (the size of the read-out at that dose, not a potency): 59%
Beside the measured number, compound 4's estimate is 15 percentage points below it, and the stated range ends below it.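

In this assay, the step for methoxy in place of chloro on the core of compound 3 is a number 11 percentage points higher from compound 3 to compound 4 (beyond the scatter), and it does not match the step on the core of compound 1: the same change on two cores in this assay, a number 5 percentage points lower (within the scatter) from compound 1 to compound 2 and a number 11 percentage points higher (beyond the scatter) from compound 3 to compound 4, 16 percentage points apart, beyond the scatter of two such steps. In this series, then, the size and direction of this change on one core cannot be assumed for the other. The comparison rests on a single pair per core, at one dose and one time, and it does not show what in the cores sets the steps apart or how large either step would be as a potency.

Going by these compounds, whether other groups on the same aromatic carbon, such as fluoro, methyl or an amine, also behave differently on the two cores remains open. So does whether the gap between the steps would persist at other doses or times.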